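A few compounds are considered here, and "the series" means these few. Any claim that something is new, unique, unknown or untested is made for them only; others in the source may bear on it.

Measured compounds:
compound 1, `C=C[C@@](C)(/C=C/c1ccc(O)cc1)CC/C=C(\C)C(=O)OCC`, > 36600 nM
compound 2, `C=C[C@@](C)(/C=C/c1ccc(O)c(CO)c1)CCC=C(C)C`, > 36600 nM

In a functional assay on SEM cells (Homo sapiens) for cytotoxicity, with a stated time of 72 h (a lower number here means that less compound is needed, a higher number that more compound is needed for the effect), compound 1 gives > 36600 nM, which is a limit of the assay and not a number. Compound 2 gives > 36600 nM, again a limit and not a number. Compound 2 therefore stands at the limit of > 36600 nM in this assay, at which 2 of the 2 values shown sit, and no numeric difference between the two measured compounds can be drawn. The next compound is compound 3, `C=C[C@@](C)(/C=C/c1ccc(O)c(/C=C/c2ccc(F)cc2)c1)CCC=C(C)C`. It differs from compound 2 in one place: 2-(4-fluorophenyl)ethenyl in place of hydroxymethyl on an aromatic carbon.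

Going by the values given here, no step between measured compounds is available to guide the size of this change. Since compound 2 sits at a limit, any movement can only be toward lower numbers or none that the assay can show. Compound 3 is expected at about 20000 nM, within 5000 nM to 80000 nM, which would mean an estimated step of an at least 1.8-fold lower number from compound 2 to compound 3 (0.26 log units; that floor lies within the scatter); a result that again reports only a limit is judged about as likely as a number.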

Compound 3, half-maximal effective concentration: > 36600 nM
Compound 3 gave a limit, no number (the forecaster's own chance of this, stated with the estimate: 50%); middle value at least 1.8-fold (0.26 log units) away from the limit.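

In this assay compound 3 gives > 36600 nM, again a limit and not a number. Going by these compounds alone, compound 2 also stands at a limit, so no step between compound 2 and compound 3 can be read. The compounds shown leave open how much of each would be needed for the effect: the limit of > 36600 nM in this assay, at which 3 of the 3 values shown sit.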